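The source may hold more compounds than are shown below. What is called first, only, known or untested is meant among the compounds shown, and "the series" means these compounds.

Measured so far:
- compound 1 `CCc1cccc2cc(C(=O)O)cnc12` gives > 50 mg/kg
- compound 2 `COc1ccc2cc(-c3nn[nH]n3)cnc2c1` gives 5 mg/kg
- compound 3 `COc1ccc2ncc(C(=O)O)cc2c1` gives > 5 mg/kg

In a functional assay on the whole organism (strain Sprague-Dawley) for inhibition, with Rattus norvegicus as the target (on this read-out higher numbers stand for an effect only at larger amounts of compound and lower numbers for an effect already at smaller amounts), compound 1 stands at a limit of the assay, not at a number. Compound 3 likewise stands at a limit, (the limit of > 5 mg/kg in this assay, at which 1 of the 3 values shown sits). Compound 2 alone gives a number in this assay, and of the three it is the only one with an effect recorded below both limits.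

Compound 4 `Cc1cccc2cc(C(=O)O)cnc12` differs from compound 1 by hydrogen in place of methyl on a saturated chain carbon bound to an aromatic carbon. Among the measured compounds shown here, no measured pair shows this change, so its effect has not been seen. The step of a number no higher from compound 1 to compound 4 (the limit leaves the size open) is expected to stay within the scatter. Compound 4 is therefore expected near 50 mg/kg, between 25 mg/kg and 100 mg/kg, most likely again as a limit.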

Compound 4, minimum effective dose: > 50 mg/kg
Compound 4 ended at the assay's limit; the forecaster's own chance of this, stated with the estimate: 75%; the middle value sits exactly at the limit.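

Among the compounds shown here, compound 1 and compound 4 both stand at a limit in this assay, so no step between them can be read. The compounds shown leave open whether hydrogen in place of methyl changes the minimum effective dose at all.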